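Bromo in place of cyano: tolerability expectation for compound 4

The source may hold more compounds than are shown below. What is called first, only, known or untested is meant among the compounds shown, and "the series" means these compounds.

Compound 3 `COc1ccc(-c2cnc(NC(=O)c3ccccc3C#N)n2C)cc1` is one of three amides built on a shared core. In a toxicity assay on THP-1 cells (Homo sapiens) for inhibition (a higher number here means that more compound is tolerated, a lower number that less compound is tolerated), compound 3 gives only a limit of the assay, > 100000 nM. Compound 1 `COc1ccc(-c2cnc(NC(=O)c3cccc(O)c3)n2C)cc1` likewise reaches only a limit in this assay, > 100000 nM. Compound 2 `COc1ccc(-c2cnc(NC(=O)c3ccccc3F)n2C)cc1` also sits at a limit, > 100000 nM. Compound 3 therefore stands level with the other two at the assay ceiling, (the limit of > 100000 nM in this assay, at which 3 of the 3 values shown sit), and no order among the three can be read from these numbers.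

The measured steps are a step that the two limits leave unreadable from compound 1 to compound 2, a step that the two limits leave unreadable from compound 1 to compound 3 and a step that the two limits leave unreadable from compound 2 to compound 3; each of them is unreadable, as both ends are limits.

Compound 4 `COc1ccc(-c2cnc(NC(=O)c3ccccc3Br)n2C)cc1` differs from compound 3 by bromo in place of cyano on an aromatic carbon. The step from compound 2 to compound 3 is the nearest analogy, a swap of one small substituent for another on an aromatic carbon, yet it too gives no readable size. Among the compounds with values here, with no measured step showing a shift in this assay, no movement beyond the scatter is expected in either direction; the expected step is a step that the limit leaves unreadable from compound 3 to compound 4. Compound 4 is estimated at 150000 nM, with a range from 60000 nM to 400000 nM, and most likely again reported only as a limit.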

Compound 4, half-maximal cytotoxic concentration: > 100000 nM
Compound 4: a limit, no number; the forecaster's own chance of this, stated with the estimate: 80%; the middle value is on the limit's open side.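

No step to compound 4 from compound 1, compound 2 or compound 3 can be read in this assay, as both ends of each step are limits: the limit of > 100000 nM in this assay, at which 4 of the 4 values shown sit.

The compounds shown leave open whether any of the four differs from another in this assay, and at what concentration any of them would reach half-maximal cytotoxicity.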